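Three thiazole ethers, one amide swap, and toxicity

This account rests on a few compounds, and the source may have more. Where it says the series, first, only, none or still open, it means among the compounds named here.

Measured so far in an ADME assay on HepG2 2.2.15 cells (Homo sapiens) for cytotoxicity; on this read-out lower numbers stand for higher toxicity in this test and higher numbers for lower toxicity in this test:
- compound 1 `Cc1cc(Br)cc(OC(c2ccc(Cl)cc2)c2cnc(NC(=O)OC(C)(C)C)s2)c1`: > 50000 nM
- compound 2 `O=C(Nc1ncc(C(OCc2ccc(Br)cc2)c2ccccc2)s1)c1cccs1`: "not toxic" (no number reported)
- compound 3 `Clc1ccc(C(Oc2ccc3cc(Br)ccc3c2)c2cnc(NCC3CCCCC3)s2)cc1`: "not toxic" (no number reported)

The value for compound 1 is a limit of the assay and not a number. Compound 2 is reported without a number. Compound 3, the starting point here, likewise carries no single number in this assay; of the three values shown, one is a limit and one more is an entry without a number, so all three compounds sit at the non-toxic end of the read-out, and no two of them can be ordered against each other.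

Compound 4 `COc1ccc(C(=O)Nc2ncc(C(Oc3ccc4cc(Br)ccc4c3)c3ccc(Cl)cc3)s2)cc1` differs from compound 3 in one place: (4-methoxyphenyl)carbonyl in place of cyclohexylmethyl on a nitrogen on an aromatic ring. The rest of the molecule, with its two aromatic ethers and the shared core, is unchanged.

For the measured compounds named here, since no step between measured compounds is available, the expectation rests on the three values alone. All of them stand in the non-toxic region, which includes the limit seen for compound 1 (the limit of > 50000 nM in this assay, at which 1 of the 3 values shown sits), so for compound 4 in this assay no shift beyond the scatter is expected, in either direction. Compound 4 is therefore estimated at 60000 nM, with a range from 20000 nM to 200000 nM.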

Compound 4, half-maximal cytotoxic concentration: > 50000 nM
Compound 4 ended at the assay's limit (the forecaster's own chance of this, stated with the estimate: 70%); the middle value does not contradict the limit.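

For the compounds shown here, compound 3 is reported without a number, and for compound 4 the entry > 50000 nM is a limit of the assay and not a number, so no step between compound 3 and compound 4 can be read. From the compounds shown here alone, still open in this assay is whether exchanging cyclohexylmethyl for (4-methoxyphenyl)carbonyl changes toxicity at all.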